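Swapping the nitrile for an ester on the aryl ring

A few compounds are considered here, and "the series" means these few. Any claim that something is new, unique, unknown or untested is made for them only; others in the source may bear on it.

Measured so far:
compound 1 `CN1CC(=O)N=C1NC(=O)Nc1cccc(C#N)c1` gives 3900 nM
compound 2 `COc1cccc(NC(=O)NC2=NC(=O)CN2C)c1` gives 2800 nM
compound 3 `CN1CC(=O)N=C1NC(=O)Nc1cccc(Br)c1` gives 380 nM

All three share a core and differ only in one group on the aromatic ring. In a functional assay for inhibition of metabotropic glutamate receptor 5 (Homo sapiens), read by FLIPR and calcium flux (a higher number here means a weaker inhibitor, a lower number a stronger inhibitor), compound 1 stands at the highest number of the three, meaning the weakest inhibition. Its nearest neighbour is compound 2, reached by a 1.4-fold lower number from compound 1 to compound 2 (0.14 log units; within the scatter), a change that does not rise above the scatter. Its furthest is compound 3, reached by a 10-fold lower number from compound 1 to compound 3 (1.01 log units; beyond the scatter), the only clear gain in this small set; compound 2 to compound 3 shows the same tendency, a 7.4-fold lower number from compound 2 to compound 3 (0.87 log units; beyond the scatter).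

Compound 4 `COC(=O)c1cccc(NC(=O)NC2=NC(=O)CN2C)c1` has not yet been measured. Its change from compound 1 is methoxycarbonyl in place of cyano on an aromatic carbon. The two measured steps from compound 1 point in different ways: the methoxy gave nothing beyond the scatter, the bromo gave a large gain. Methoxycarbonyl resembles neither closely, so the expectation rests on the weaker of the two signals. For compound 4 the step from compound 1 is expected to stay small, a 1.1-fold lower number from compound 1 to compound 4 (0.05 log units; within the scatter). Compound 4 is therefore estimated at 3500 nM, with a range from 1400 nM to 9000 nM.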

Compound 4, half-maximal inhibitory concentration: > 10000 nM
Compound 4: a limit, no number (the forecaster's own chance of this, stated with the estimate: 10%); middle value at least 2.8-fold (0.45 log units) away from the limit.
By their numbers in this assay, from the lowest: compound 3; then compounds 2 and 1 (each within the scatter of the next). At a limit, above all of these: compound 4.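

In this assay, compound 4 carries a limit and not a number: the limit of > 10000 nM in this assay, at which 1 of the 4 values shown sits.

Even so, the step can be read, and it shows something new: no earlier replacement of the cyano group had raised the number beyond the scatter, whereas here there is an at least 2.5-fold higher number from compound 1 to compound 4 (0.40 log units; beyond the scatter). This aromatic carbon can therefore lose activity as well as gain it, and the same holds against the other two groups, with an at least 3.5-fold higher number from compound 2 to compound 4 (0.55 log units; beyond the scatter) and an at least 26-fold higher number from compound 3 to compound 4 (1.42 log units; beyond the scatter), so methoxycarbonyl sits clearly apart from methoxy and bromo, and each of these steps gives only a minimum size.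

The compounds shown leave open which part of the methoxycarbonyl group goes with this loss, and whether a carboxylic acid or a simple amide on the same aromatic carbon would behave in the same way. They also leave open whether a chloro or methyl group there would keep the stronger inhibition of compound 3, and how far beyond its limit compound 4 truly lies.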